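The source may hold more compounds than are shown below. What is called first, only, known or untested is meant among the compounds shown, and "the series" means these compounds.

Measured so far in an ADME assay on S9 fraction from liver (Rattus norvegicus) for metabolic stability, read by LC-MS, using NADPH, with a stated time of 30 min; a higher number here means that more of the compound is left, a lower number that less of the compound is left:

- compound 1, `CCCCCCCCc1ccc(OC(C)C(=O)Cn2nnc(-c3ccccc3)n2)cc1`: 40%
- compound 2, `CC(Oc1ccc(Oc2ccc(F)cc2)cc1)C(=O)Cn1nnc(-c2ccccc2)n1`: reported only as a limit, see below
- compound 3, `CCCCCCCCc1ccc(OC(C)C(=O)Cn2nnc(-c3ccc(C(=O)OC)cc3)n2)cc1`: 62%

Compound 2 is reported at a limit of this assay, < 5%, which is a limit and not a number (the limit of < 5% in this assay, at which 1 of the 3 values shown sits).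

The change from compound 1 to compound 2 is 4-fluorophenoxy in place of octyl on an aromatic carbon and it produced a number at least 35 percentage points lower from compound 1 to compound 2 (beyond the scatter). The change from compound 1 to compound 3 is methoxycarbonyl in place of hydrogen on an aromatic carbon and it produced a number 22 percentage points higher from compound 1 to compound 3 (beyond the scatter); compound 3 holds the higher of the two numbers reported.

Compound 4, `COC(=O)c1ccc(-c2nnn(CC(=O)C(C)Oc3ccc(Oc4ccc(F)cc4)cc3)n2)cc1`, is not yet measured. It differs from compound 3 by 4-fluorophenoxy in place of octyl on an aromatic carbon. The two cores differ by methoxycarbonyl in place of hydrogen on an aromatic carbon. The place lines of both changes read the same, so this is the same kind of change made once more. Among the measured compounds shown here, the step from compound 3 to compound 4 is expected to be a number 50 percentage points lower from compound 3 to compound 4 (beyond the scatter), large and downward, resting on the single earlier pair, a number at least 35 percentage points lower from compound 1 to compound 2 (beyond the scatter), which started from a lower value in compound 1, 40%. Compound 4 is expected to give 12%, estimated between 3% and 30%, with a real chance that only a limit is reported.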

Compound 4, percent of the compound remaining: < 5%
Compound 4: a limit, no number (the forecaster's own chance of this, stated with the estimate: 40%); middle value at least 7 percentage points away from the limit.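

In this assay, compound 4 is reported at < 5%, which is a limit and not a number. Placing 4-fluorophenoxy in place of octyl on the core of compound 3 gives a number at least 57 percentage points lower from compound 3 to compound 4 (beyond the scatter). The direction of this change therefore carries over between the two cores in this small set, but its size on one core cannot be compared with its size on the other: the same change on two cores in this assay, a number at least 35 percentage points lower (beyond the scatter) from compound 1 to compound 2 and a number at least 57 percentage points lower (beyond the scatter) from compound 3 to compound 4; the limit leaves it open whether they differ

From the compounds shown here alone, the step for methoxycarbonyl in place of hydrogen between compound 2 and compound 4 cannot be read, so its effect with 4-fluorophenoxy present remains open: the limit of < 5% in this assay, at which 2 of the 4 values shown sit. Also open is whether a shorter alkyl chain, an amine or a carboxylic acid in place of octyl would leave more of the compound than 4-fluorophenoxy does, and whether any such group would keep the read-out clear of the limit.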